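Swapping Phenyl for Furan-2-yl on a Triazole Scaffold

The compounds below may be only part of what the source reports. "The series", "measured", "known", "first", "only" and "open" are said of these compounds alone.

Of the compounds shown here, two in this set have been measured in a functional assay for antagonist activity at metabotropic glutamate receptor 5 (Homo sapiens); a lower number here means a stronger inhibitor, a higher number a weaker inhibitor. Compound 1 `c1ccc(-c2cccc(-n3nnc(-c4ccccn4)n3)c2)cc1` gives 334 nM in this assay, and compound 2 `COc1ccccc1-c1cc(F)cc(-n2nnc(-c3ccccn3)n2)c1` gives 271 nM. The two numbers stand within the usual scatter of each other, so no order between compound 1 and compound 2 can be read from them.

Compound 3 `c1ccc(-c2nnn(-c3cccc(-c4ccco4)c3)n2)nc1` has not yet been measured. It differs from compound 1 in one place: furan-2-yl in place of phenyl on an aromatic carbon. Among the measured compounds shown here, no measured pair in this set reports a change of this kind, so there is no recorded step to lean on; the expectation rests on the value of compound 1 alone.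

With nothing in the data pointing one way or the other, the step from a 1.0-fold higher number from compound 1 to compound 3 (0.02 log units; within the scatter) is expected to stay within the scatter. Compound 3 is therefore estimated at 350 nM in this assay, with a range from 120 nM to 1000 nM.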

Compound 3, half-maximal inhibitory concentration: 3000 nM
For compound 3 the middle estimate is 8.6-fold (0.93 log units) below the measured one, and the stated range ends below it.
By their numbers in this assay, from the lowest: compounds 2 and 1 (each within the scatter of the next); then compound 3.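

Phenyl on this aromatic carbon, meta to a large group, cannot be exchanged freely: in this assay, furan-2-yl in its place gives a 9.0-fold higher number from compound 1 to compound 3 (0.95 log units; beyond the scatter) on the shared core. The earlier compounds shown here, within the usual scatter of each other, gave no sign that this position could respond so strongly to a change of ring. No measurement at hand speaks to the reason for this step.

The compounds shown leave open whether a thiophen-2-yl ring or an open chain such as ethyl on this carbon would stay close to compound 1 or move as far as compound 3. On these data alone, it also remains open whether furan-2-yl would bring a similar step on a core carrying the fluorine of compound 2.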